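Aryl for cyclohexyl on the amide nitrogen of compound 1

The source may report more compounds than this note shows. Statements on the series, on what has been measured and on what is new or still open speak of the compounds shown alone.

Measured compounds:
- compound 1, `O=C(CN1CCC(c2cccc[n+]2[O-])CC1)NC1CCCCC1`: 294 nM
- compound 2, `C=Cc1cccc(C(=O)NCN2CCC(c3cccc[n+]3[O-])CC2)c1`: 68 nM

Two compounds with the same core carry a measurement in a functional assay on HEK293 cells for agonist activity at D(4) dopamine receptor (Homo sapiens), read by FLIPR; on this read-out lower numbers stand for an effect already at smaller amounts and higher numbers for an effect only at larger amounts of compound. Compound 1 `O=C(CN1CCC(c2cccc[n+]2[O-])CC1)NC1CCCCC1` gives 294 nM, which is the higher of the two numbers. Compound 2 `C=Cc1cccc(C(=O)NCN2CCC(c3cccc[n+]3[O-])CC2)c1` gives 68 nM; this lies beyond the scatter of repeated measurements from the value of compound 1, and the two compounds differ in more than one place, so no single change accounts for the gap.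

Compound 3 `Cc1cc(F)ccc1NC(=O)CN1CCC(c2cccc[n+]2[O-])CC1` differs from compound 1 in one place: 4-fluoro-2-methylphenyl in place of cyclohexyl on an amide-type nitrogen. Among the measured compounds shown here, no pair of measured compounds shows this change, so the size of its effect is unknown. An aromatic ring in place of the saturated one on the amide nitrogen is expected to lower the number only modestly, close to the edge of the scatter. The estimated step from compound 1 to compound 3 in this assay is a 1.7-fold lower number from compound 1 to compound 3 (0.24 log units; within the scatter). Compound 3 is thus expected to give about 170 nM, with a plausible range from 50 nM to 600 nM.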

Compound 3, half-maximal effective concentration: 60 nM
Compound 3: the middle estimate sits 2.8-fold (0.45 log units) above what was measured; measured number inside the range.
By their numbers in this assay, from the lowest: compounds 3 and 2 (each within the scatter of the next); then compound 1.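

In this assay, the amide-type nitrogen of the core of compound 1 emerges as a place where the group carried matters: 4-fluoro-2-methylphenyl in place of cyclohexyl brings a 4.9-fold lower number from compound 1 to compound 3 (0.69 log units; beyond the scatter). Among the compounds shown here, the earlier pair differed in more than one place, so this is the first step that can be tied to a single change. The change swaps a non-aromatic ring for an aromatic one and adds a fluorine and a methyl in the same move, and nothing at hand bears on why the number falls.

On these data alone, what stays open is how much of the step belongs to the aromatic ring itself and how much to the fluorine and the methyl, a question that plain phenyl on the same nitrogen would help to settle. Also open, as far as these compounds go, is whether the gain survives other groups at this place, such as benzyl, which sets a carbon chain in front of the ring, or a phenyl ring bearing an amine or a carboxylic acid.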